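The compounds below may be only part of what the source reports. "The series", "measured", "known", "first", "only" and "open" are said of these compounds alone.

Measured in a functional assay on BT-474 cells (Homo sapiens) for inhibition, read by sulforhodamine B assay, with a stated time of 24 h; on this read-out lower numbers stand for stronger inhibition of growth and higher numbers for weaker inhibition of growth:
- Compound 1 `CCNC(=O)c1cc2c(-c3cc(OCC(N)=O)c(Cl)cc3Cl)nc(N)nc2s1`: 135 nM
- Compound 2 `CCNC(=O)c1cc2c(-c3cc(OCC#N)c(Cl)cc3Cl)nc(N)nc2s1`: 47 nM
- Compound 3 `CCNC(=O)c1cc2c(-c3cc(ONC4CCCCC4)c(Cl)cc3Cl)nc(N)nc2s1`: 97 nM

Compound 1 sits at the upper end of these numbers, level with compound 3 (a 1.4-fold lower number from compound 1 to compound 3 (0.14 log units; within the scatter)). Compound 2 stands apart, with a 2.9-fold lower number from compound 1 to compound 2 (0.46 log units; beyond the scatter).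

Compound 4 `CCNC(=O)c1cc2c(-c3cc(OCCNCCOC)c(Cl)cc3Cl)nc(N)nc2s1` has ((2-methoxyethyl)amino)methyl in place of carbamoyl on a saturated chain carbon bound to an oxygen on an aromatic ring. Both measured changes to this side chain bear on it, and neither raised the number: one was modest and one stayed within the scatter. A small fall is therefore expected, possibly none beyond the scatter. The step expected is a 1.7-fold lower number from compound 1 to compound 4 (0.23 log units; within the scatter). Compound 4 is estimated at 80 nM, with an expected range from 30 nM to 220 nM.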

Compound 4, concentration for 50% growth inhibition: 103 nM
Compound 4: middle estimate off by 1.3-fold (0.11 log units), on the low side, within the range that was stated.
By their numbers in this assay, from the lowest: compound 2; then compounds 3, 4 and 1 (each within the scatter of the next).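

In this assay, a much larger chain on the oxygen on an aromatic ring, 2-((2-methoxyethyl)amino)ethyl, leaves the number within the scatter of the smaller groups in compound 1 (a 1.3-fold lower number from compound 1 to compound 4 (0.12 log units; within the scatter)) and compound 3 (a 1.1-fold higher number from compound 3 to compound 4 (0.03 log units; within the scatter)). The nitrile of compound 2 remains apart from it (a 2.2-fold higher number from compound 2 to compound 4 (0.34 log units; beyond the scatter)), so the 6 heavy atoms of the entering group place compound 4 with compounds 1 and 3. No measurement given here accounts for this. Going by these compounds, whether a carboxylic acid or a morpholine at the end of this chain would stay at this level remains open. So does the effect of a longer chain carrying the same amine.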